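The compounds below may be only part of what the source reports. "The series", "measured", "known", "first", "only" and "open" are said of these compounds alone.

Compound 3 `N/C(=N\NC(=S)N1CCCC1)c1ccccn1` was tested in a functional assay on A-375 cells (Homo sapiens) for cytotoxicity, read by MTT assay, with a stated time of 72 h, tested at 3 uM (on this read-out lower numbers stand for less inhibition of growth and higher numbers for more inhibition of growth at the one concentration tested), where compound 3 gives 80%. Compound 1 `N/C(=N\NC(=S)N1CCSCC1)c1ccccn1` gives 80%, and no change at the digits printed from compound 1 to compound 3 (within the scatter), so the two stand level and together at the top of the three numbers. Compound 2 `N/C(=N\NC(=S)N1CCOCC1)c1ccc(F)cn1` gives 66.4%, a number lower than compound 3 by more than the scatter. Compound 4 `N/C(=N\NC(=S)N1CCCC1)c1ccc(F)cn1` differs from compound 3 by fluoro in place of hydrogen on an aromatic carbon. For the measured compounds named here, no measured step isolates this change: compound 2 also carries fluoro, but it differs from compound 3 in a second place as well, so its lower number cannot be assigned to the fluoro alone. A small drop, or none beyond the scatter, is therefore expected, a number 8 percentage points lower from compound 3 to compound 4 (within the scatter). Compound 4 is estimated at 72%, within 55% to 85%.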

Compound 4, percent growth inhibition at one concentration: 81.8%
The estimate for compound 4 lay 9.8 percentage points below the measured number; the measured number falls inside the stated range.
By their numbers in this assay, from the lowest: compound 2; then compounds 1, 3 and 4 (each within the scatter of the next).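

The fluoro change now stands alone: in this assay there is a number 1.8 percentage points higher from compound 3 to compound 4 (within the scatter), so fluoro in place of hydrogen on this aromatic carbon, para to a large group, shows no change beyond the scatter. With fluoro in both compounds, pyrrolidin-1-yl in place of morpholin-4-yl gives a number 15.4 percentage points higher from compound 2 to compound 4 (beyond the scatter), so the lower number of compound 2 goes with the morpholin-4-yl group and not with the fluoro. Still open, as far as these compounds go, is how chloro, methoxy or an amine on this same aromatic carbon would read. No measurement at hand explains either step.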